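The compounds below may be only part of what the source reports. "The series", "measured", "known", "first", "only" and "open" are said of these compounds alone.

Among the measured compounds shown here, in an assay on mitochondria (strain BALB/c) for inhibition of glycerol-3-phosphate acyltransferase 1, mitochondrial (Mus musculus), read by scintillation counting, with a stated time of 10 min (on this read-out lower numbers stand for stronger inhibition and higher numbers for weaker inhibition), compound 3 `CCCCCCCCS(=O)(=O)Nc1ccc(-c2ccccc2OC)cc1C(=O)O` gives 27600 nM, the highest of the three numbers measured so far. Compound 1 `CCCCCCCCS(=O)(=O)Nc1cc(-c2ccc(-c3ccccc3)cc2)ccc1C(=O)O` gives 13500 nM and compound 2 `CCCCCCCCS(=O)(=O)Nc1ccc(-c2ccccc2-c2ccccc2)cc1C(=O)O` gives 10100 nM in this assay. Compound 4 `CCCCCCCCS(=O)(=O)Nc1ccc(/C=C/c2ccccc2)cc1C(=O)O` differs from compound 3 by 2-phenylethenyl in place of 2-methoxyphenyl on an aromatic carbon. For the measured compounds named here, the only step measured in one place is a 2.7-fold higher number from compound 2 to compound 3 (0.44 log units; beyond the scatter), which sets a methoxy against a phenyl rather than a 2-phenylethenyl, so it bears on the present change only loosely. Going by the values given here, because compound 2 carries a second aromatic ring and gives 10100 nM, a return toward a lower number seems plausible, but no measured compound carries a double bond outside aromatic rings. A modest step toward a lower number in this assay is therefore expected, a 2.3-fold lower number from compound 3 to compound 4 (0.36 log units; beyond the scatter). Compound 4 is estimated at 12000 nM, with a range from 4000 nM to 36000 nM.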

Compound 4, half-maximal inhibitory concentration: 16300 nM
For compound 4 the middle estimate is 1.4-fold (0.13 log units) below the measured one; the measured number falls inside the stated range.
By their numbers in this assay, from the lowest: compounds 2, 1, 4 and 3 (each within the scatter of the next, the first and the last beyond it).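

Setting 2-phenylethenyl in place of 2-methoxyphenyl on this aromatic carbon, para to a large group, gives in this assay a 1.7-fold lower number from compound 3 to compound 4 (0.23 log units; within the scatter) and so does not separate the two groups. At this position, then, a swap that keeps the same count of heavy atoms and one aromatic ring, gains a double bond outside aromatic rings and loses a hydrogen-bond acceptor, leaves the number within the usual scatter. No measurement offers an explanation for this result.

Still open, as far as these compounds go, is whether an amide linker in place of the double bond would read differently here. So too is whether a pyridine ring in place of the terminal phenyl would do so.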